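Methyl for carboxy on the indole of a pyrimidine sulfone

A few compounds are considered here, and "the series" means these few. Any claim that something is new, unique, unknown or untested is made for them only; others in the source may bear on it.

Measured compounds:
compound 1, `Cn1c(=O)c(S(=O)(=O)c2ccc(F)cc2F)cc2cnc(Nc3ccc4[nH]c(C(=O)O)cc4c3)nc21`: 10000 nM
compound 2, `Cn1c(=O)c(S(=O)(=O)c2ccc(Cl)cc2Cl)cc2cnc(Nc3ccc4[nH]ccc4c3)nc21`: 1000 nM
compound 3, `O=c1c(S(=O)(=O)c2ccc(F)cc2F)cc2cnc(Nc3ccc4[nH]ccc4c3)nc2n1C1CCCC1`: 5000 nM

These three compounds share one core and were tested in a functional assay on K562 cells (Homo sapiens) for inhibition, read by trypan blue exclusion, with a stated time of 72 h; a higher number here means a weaker inhibitor, a lower number a stronger inhibitor. Compound 1 gives the highest of the three numbers, 10000 nM. Compound 3 comes nearest to it with 5000 nM, a gap that lies within the scatter, so the two are not distinguished here. Compound 2, with 1000 nM, stands further off, and that gap lies beyond the scatter. Among the measured compounds shown here, compound 2 and compound 3 differ from compound 1 in more than one place, so no single step among the measured compounds is defined.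

Compound 4, `Cc1cc2cc(Nc3ncc4cc(S(=O)(=O)c5ccc(F)cc5F)c(=O)n(C)c4n3)ccc2[nH]1`, is unmeasured. It differs from compound 1 in one place: methyl in place of carboxy on an aromatic carbon. Read one bond further out, the 2-carboxy-1H-indol-5-yl group becomes 2-methyl-1H-indol-5-yl.

For the measured compounds named here, no measured pair isolates this change, so the expectation rests on the three numbers alone. Because compound 2 gives 1000 nM and compound 3 gives 5000 nM, both without the carboxy group, the step from compound 1 is expected to run toward a lower number, of modest size, a 3.3-fold lower number from compound 1 to compound 4 (0.52 log units; beyond the scatter). Compound 4 is thus estimated at 3000 nM, with a range from 1000 nM to 10000 nM in this assay.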

Compound 4, half-maximal inhibitory concentration: 750 nM
Beside the measured number, compound 4's estimate is 4.0-fold (0.60 log units) above it, and the stated range ends above it.
By their numbers in this assay, from the lowest: compounds 4 and 2 (each within the scatter of the next); then compounds 3 and 1 (each within the scatter of the next).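

In this assay, putting methyl in place of carboxy on the aromatic carbon next to the ring nitrogen gives a 13-fold lower number from compound 1 to compound 4 (1.12 log units; beyond the scatter), a large step beyond the scatter. This is the first comparison among these compounds that isolates this position: compound 2 and compound 3 differ from compound 1 in more than one place and so could not tie any difference to the carboxy group, whereas here the rest of the molecule is held fixed and the 2-methyl-1H-indol-5-yl group alone separates compound 4 from the 2-carboxy-1H-indol-5-yl group of compound 1. The change removes a carbonyl and the hydrogen-bond donor and acceptor counted for carboxy, but nothing available here accounts for the step or says which of these differences matters.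

Still open, from the compounds shown here alone, is how a methyl ester, a primary amide, a hydroxymethyl group or a plain hydrogen at this carbon would compare with methyl and carboxy. Going by these compounds, it is also open whether the step would carry over to the dichlorophenyl sulfone of compound 2 or the cyclopentyl group of compound 3.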